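The compounds below may be only part of what the source reports. "The series", "measured", "known", "first", "only" and "open" are said of these compounds alone.

Of the compounds shown here, three have been measured in a physicochemical assay for lipophilicity, at pH 7.4 (a higher number here means a more lipophilic compound, a lower number a more polar compound), so far. Compound 1 `CNC(=O)c1cc(C(=O)NC2CC2)cn(Cc2cccc(F)c2)c1=O` gives 3.2, compound 2 `CNC(=O)c1cc(C(=O)NCCC2CCOCC2)cn(Cc2ccccc2)c1=O` gives 3.6, and compound 3 `CNC(=O)c1cc(C(=O)NC2CC2)cn(Cc2cccc3cn[nH]c23)c1=O` gives 2.2, the lowest of the three. Among the compounds with values here, the one measured step that reaches compound 3 is a number 1.00 log units lower from compound 1 to compound 3 (beyond the scatter). Compound 4 `CNC(=O)c1cc(C(=O)NC2CC2)cn(Cc2cccc3occc23)c1=O` is the next step: 1-benzofuran-4-yl in place of 1H-indazol-7-yl on a saturated chain carbon bound to an aromatic nitrogen. The same kind of swap, a group with one hydrogen-bond donor against one with none on that saturated chain carbon, moved the number upward by a modest amount when run from compound 3 back toward compound 1, so a step of similar size upward is expected here, a number 1.10 log units higher from compound 3 to compound 4 (beyond the scatter). Compound 4 is therefore estimated at 3.3, within a range from 2.8 to 3.8.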

Compound 4, distribution coefficient: 3.4
Compound 4: the middle estimate sits 0.10 log units below what was measured; the measured number falls inside the stated range.
By their numbers in this assay, from the lowest: compound 3; then compounds 1, 4 and 2 (each within the scatter of the next, the first and the last beyond it).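

In this assay the swap from 1H-indazol-7-yl to 1-benzofuran-4-yl on this saturated chain carbon gives a number 1.20 log units higher from compound 3 to compound 4 (beyond the scatter) and is a large step between two groups with the same count of heavy atoms. The 1-benzofuran-4-yl and 3-fluorophenyl groups, neither carrying a hydrogen-bond donor, cannot be told apart here, with a number 0.20 log units higher from compound 1 to compound 4 (within the scatter) and only compound 3 standing apart. From the compounds shown here alone, how a group bearing an amine or a carboxylic acid would read at this place stays open. Nothing shown explains these steps or ties them to the hydrogen-bond donor.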